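A New Group on the Five-Membered Ring of Compound 3

This account rests on a few compounds, and the source may have more. Where it says the series, first, only, none or still open, it means among the compounds named here.

Three compounds share one core and differ only in the group attached to a five-membered aromatic ring with four nitrogen atoms. In an assay on Sf9 cells for inhibition of protein deacetylase HDAC6 (Homo sapiens), read by fluorescence (on this read-out higher numbers stand for weaker inhibition and lower numbers for stronger inhibition), compound 1 `O=C(NO)c1ccc(Cn2nnc(Cc3ccccn3)n2)cc1` gives 25 nM. Compound 2 `O=C(NO)c1ccc(Cn2nnc(-c3ccc(C(F)(F)F)cc3)n2)cc1` gives 11 nM, and compound 3 `O=C(NO)c1ccc(Cn2nnc(-c3ncccn3)n2)cc1` gives 7 nM, the lowest of the three numbers. Among the measured compounds shown here, the only one-place comparison available is a 3.6-fold lower number from compound 1 to compound 3 (0.55 log units; beyond the scatter). The numbers for compound 2 and compound 3 lie within the scatter of each other, so the two groups that sit directly on the five-membered ring cannot be told apart on these data.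

Compound 4 `NCc1ccc(-c2nnn(Cc3ccc(C(=O)NO)cc3)n2)cc1` has not yet been measured. It differs from compound 3 in that (4-(aminomethyl)phenyl in place of pyrimidin-2-yl on an aromatic carbon). As in compound 2 and compound 3, the new group is again a six-membered ring joined directly to the five-membered ring, and for that pairing compound 2 gives 11 nM while compound 3 gives 7 nM. For the measured compounds named here, no measured step speaks to the aminomethyl group itself. The step of a 1.7-fold higher number from compound 3 to compound 4 (0.23 log units; within the scatter) is therefore expected to be small, within or only just beyond the scatter. Compound 4 is expected to give about 12 nM in this assay, most likely between 4 nM and 40 nM.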

Compound 4, half-maximal inhibitory concentration: 2 nM
Compound 4: the middle estimate sits 6.0-fold (0.78 log units) above what was measured, outside the stated range (below it).
By their numbers in this assay, from the lowest: compound 4; then compounds 3 and 2 (each within the scatter of the next); then compound 1.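

In this assay the groups joined directly to the five-membered ring could not be told apart in compound 2 and compound 3, but the change to 4-(aminomethyl)phenyl gives a 3.5-fold lower number from compound 3 to compound 4 (0.54 log units; beyond the scatter), so a group at this position can move the number beyond the scatter. The comparison with the closest structure changes only the group carried by the phenyl ring, with aminomethyl in place of trifluoromethyl, and it gives a 5.5-fold lower number from compound 2 to compound 4 (0.74 log units; beyond the scatter); what matters here is therefore not just the kind of ring joined to the five-membered ring, but also what that ring carries. The widest step in the set is a 13-fold lower number from compound 1 to compound 4 (1.10 log units; beyond the scatter), and nothing measured here says why any of these steps arises.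

Going by these compounds, it remains open whether the amine itself counts or only the presence of a short chain on the phenyl ring, a question that a hydroxymethyl group, a carboxylic acid or a longer aminoethyl chain in place of aminomethyl could help settle. A plain phenyl group would show whether the unsubstituted ring falls closer to compound 2 or to compound 4.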